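A few compounds are considered here, and "the series" means these few. Any claim that something is new, unique, unknown or untested is made for them only; others in the source may bear on it.

For the measured compounds named here, compound 2 `Nc1ccc(C2=NN(c3ccc(Cl)cc3)C(c3ccc(O)cc3)C2)cc1` stands highest of the two numbers so far: in an assay on isolated protein for inhibition of protein kinase C zeta type (Homo sapiens), with a stated time of 4 min, tested at 62.5 uM (on this read-out lower numbers stand for less inhibition and higher numbers for more inhibition at the one concentration tested (going by the name of the read-out)), compound 2 gives 98%, while compound 1 `CCOc1ccccc1C1=NN(c2ccc(Cl)cc2)C(c2ccc(O)cc2)C1` gives 42.8%. Going by the values given here, the single recorded step, a number 55.2 percentage points higher from compound 1 to compound 2 (beyond the scatter), bears directly on compound 3 `CC1=NN(c2ccc(Cl)cc2)C(c2ccc(O)cc2)C1`, where (methyl in place of 4-aminophenyl on a carbon with a double bond to nitrogen). That step shows the group on this carbon shifts the read-out strongly, so with methyl in place of 4-aminophenyl a downward step beyond the scatter is expected for compound 3, a number 58 percentage points lower from compound 2 to compound 3 (beyond the scatter). Compound 3 is therefore estimated at 40% in this assay, with a range from 10% to 75%.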

Compound 3, a percentage reported as inhibition, at one concentration (the size of the read-out at that concentration, not a potency): 58.8%
Estimate against measurement, compound 3: 18.8 percentage points below; the measured number falls inside the stated range.
By their numbers in this assay, from the lowest: compound 1; then compound 3; then compound 2.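

In this assay, methyl on this carbon gives a number 39.2 percentage points lower from compound 2 to compound 3 (beyond the scatter) and also a number 16 percentage points higher from compound 1 to compound 3 (beyond the scatter) so the three groups spread over a wide range. The ringless methyl sits between the two aryl groups, so a six-membered aromatic ring here does not by itself give the higher number: 4-aminophenyl lies above methyl and 2-ethoxyphenyl below it.

Going by these compounds, whether an aminomethyl group or a longer alkyl chain on this carbon would read nearer compound 2 or compound 3 stays open. Nothing available explains this order of the three groups.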